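Phenyl in place of arylamino: cytotoxicity notes

A few compounds are considered here, and "the series" means these few. Any claim that something is new, unique, unknown or untested is made for them only; others in the source may bear on it.

Compound 1, `COc1cc(-c2nn(-c3cccc(NC(=O)c4ccc(Cl)c(C(F)(F)F)c4)c3)cc2-c2ccncc2)ccc1Cl`, in a functional assay on IGROV-1 cells (Homo sapiens) for inhibition, read by sulforhodamine B assay, with a stated time of 48 h (on this read-out higher numbers stand for lower toxicity in this test and lower numbers for higher toxicity in this test), gives > 32500 nM, which is a limit of the assay and not a number.
Compound 2, `COc1cc(-c2nn(-c3cccc(NC(=O)Nc4ccc(Cl)c(C(F)(F)F)c4)c3)cc2-c2ccncc2)ccc1Cl`, in this assay gives > 32500 nM, again only a limit.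

For the measured compounds named here, compound 2 therefore stands at a limit in this assay and nowhere else: the sole measured step, a step that the two limits leave unreadable from compound 1 to compound 2, is unreadable because both of its ends are limits, and the limit of > 32500 nM in this assay, at which 2 of the 2 values shown sit, is the whole of the evidence. Compound 3, `COc1cc(-c2nn(-c3cccc(NC(=O)c4ccccc4)c3)cc2-c2ccncc2)ccc1Cl`, differs from compound 2 by phenyl in place of (4-chloro-3-(trifluoromethyl)phenyl)amino on a carbonyl carbon. Going by the values given here, no measured step bears on this change, since the only step recorded cannot be sized. The expectation for compound 3 in this assay thus rests solely on the fact that both measured compounds sit at the limit, and the step expected is a step that the limit leaves unreadable from compound 2 to compound 3, with no direction beyond the scatter that the data would support. Compound 3 is accordingly estimated at 40000 nM, with a range from 12000 nM to 120000 nM, and a further limit rather than a number is the most likely outcome.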

Compound 3, concentration lethal to 50% of the cells: > 100000 nM
Compound 3: a limit, no number (the forecaster's own chance of this, stated with the estimate: 70%); middle value at least 2.5-fold (0.39 log units) from the limit.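

In this assay compound 3 gives > 100000 nM, a limit of the assay and not a number. None of the steps among compound 1, compound 2 and compound 3 can be read. Left open is whether phenyl, 4-chloro-3-(trifluoromethyl)phenyl and (4-chloro-3-(trifluoromethyl)phenyl)amino on the carbonyl carbon differ at all in toxicity in this assay.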